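A few compounds are considered here, and "the series" means these few. Any claim that something is new, unique, unknown or untested is made for them only; others in the source may bear on it.

Measured so far in an ADME assay on HEp-2 cells (Homo sapiens) for cytotoxicity, read by trypan blue exclusion, with a stated time of 24 h; on this read-out higher numbers stand for lower toxicity in this test and lower numbers for higher toxicity in this test:

- compound 1 `C/C(=N\N=C1/SCC(=O)N1Cc1cccc(Cl)c1)c1ccccn1`: 21 ug/mL
- compound 2 `O=C1CS/C(=N\N=C2CCCC2)N1Cc1ccccc1F`: 11 ug/mL

Repeated measurements of this kind never agree exactly, so a small gap between two numbers may mean nothing. That is the case here: compound 2 stands within the usual scatter of compound 1, and the two values cannot be ranked. For the measured compounds named here, the two structures also differ in more than one place, so this pair gives no clean single-change step to learn from.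

The next molecule is compound 3 `O=C1CS/C(=N\N=C2CCCC2)N1Cc1ccc(Cl)cc1`. It has 4-chlorophenyl in place of 2-fluorophenyl on a saturated chain carbon bound to an amide-type nitrogen in a ring, and the rest of compound 2 stays as it is: 4-chlorophenyl in place of 2-fluorophenyl on a saturated chain carbon bound to an amide-type nitrogen in a ring.

Going by the values given here, no measured pair shows what this swap does in this assay. With only compound 2 at 11 ug/mL and compound 1 at 21 ug/mL as guides, no shift beyond the scatter is expected, in either direction. The expected change is a 1.3-fold higher number from compound 2 to compound 3 (0.10 log units; within the scatter). For compound 3 the estimated value is 14 ug/mL, with an expected range from 5 ug/mL to 35 ug/mL.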

Compound 3, half-maximal cytotoxic concentration in the HEp-2 assay: 16 ug/mL
Compound 3: the middle estimate sits 1.1-fold (0.06 log units) below what was measured; the measured number falls inside the stated range.
By their numbers in the HEp-2 assay, from the lowest: compounds 2, 3 and 1 (each within the scatter of the next).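

For the compounds shown here, in the HEp-2 assay, putting 4-chlorophenyl in place of 2-fluorophenyl on a saturated chain carbon bound to an amide-type nitrogen in a ring gives the first step that changes one place only: a 1.5-fold higher number from compound 2 to compound 3 (0.16 log units; within the scatter). This pair therefore cannot be ranked, and in this test the exchange of these two groups shows no effect that can be told apart from the ordinary spread of repeated measurements. In a physicochemical assay, with a stated time of 30 min (on this read-out lower numbers stand for stronger inhibition and higher numbers for weaker inhibition), compound 2 gives > 5000000 nM (a limit of the assay and no actual number). In the physicochemical assay compound 3 gives > 5000000 nM (also a limit of the assay and no actual number). The step between them therefore cannot be read: the limit of > 5000000 nM in the physicochemical assay, at which 2 of the 2 values shown sit.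

The step exchanges the halogen and its place on the phenyl ring together, so a group such as 4-fluorophenyl would be needed to look at each of the two alone. Going by these compounds, it also stays open whether a group of a different kind on this carbon, such as a phenyl ring carrying a carboxylic acid or an amine, would move the number in the HEp-2 assay beyond the scatter, or give a readable number in the physicochemical assay.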